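This account rests on a few compounds, and the source may have more. Where it says the series, first, only, none or still open, it means among the compounds named here.

Compound 1 `O=C1/C(=C/c2ccccc2F)CN(S(=O)(=O)c2ccc(F)cc2)C/C1=C\c1ccccc1F`: 8370 nM
Compound 2 `CC(=O)Nc1ccc(S(=O)(=O)N2C/C(=C\c3ccccc3F)C(=O)/C(=C/c3ccccc3F)C2)cc1`: 7490 nM

Going by the values given here, in a functional assay on SMMC-7721 cells (Homo sapiens) for cytotoxicity, read by MTT assay, with a stated time of 24 h (a lower number here means a stronger inhibitor, a higher number a weaker inhibitor), compound 1 gives 8370 nM and stands within the scatter of compound 2, the only other compound measured. Compound 3 `O=C1/C(=C/c2cccc([N+](=O)[O-])c2)CN(S(=O)(=O)c2ccc(F)cc2)C/C1=C\c1ccccc1F` keeps the core of compound 1 and changes one group: 3-nitrophenyl in place of 2-fluorophenyl on a double-bonded chain carbon bound to a double-bonded ring carbon. Among the compounds with values here, the sole measured step is a 1.1-fold lower number from compound 1 to compound 2 (0.05 log units; within the scatter). That step replaces fluoro by acetamido on an aromatic carbon, so it does not touch the place that changes in compound 3. Within the data shown here, no measured compound shows what a change at the double-bonded chain carbon does. The data therefore give no direction, and no shift beyond the scatter is expected, though the uncertainty is wide. The expected step is a 1.1-fold lower number from compound 1 to compound 3 (0.05 log units; within the scatter). For compound 3 the estimated value is 7500 nM, with an expected range of 2800 nM to 20000 nM.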

Compound 3, half-maximal inhibitory concentration: 7820 nM
Estimate against measurement, compound 3: 1.0-fold (0.02 log units) below; measured number inside the range.
By their numbers in this assay, from the lowest: compounds 2, 3 and 1 (each within the scatter of the next).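

In this assay, going by these compounds alone, the step at this position is a 1.1-fold lower number from compound 1 to compound 3 (0.03 log units; within the scatter), so the double-bonded chain carbon, which no earlier pair had touched, now has a measured change of its own. Placing 3-nitrophenyl there in place of 2-fluorophenyl, a larger group carrying hydrogen-bond acceptors that the leaving group lacks, leaves the number within the scatter, and the one other measured step, a 1.1-fold lower number from compound 1 to compound 2 (0.05 log units; within the scatter), at an aromatic carbon, is also within the scatter. No measurement on hand offers an account of this result.

The compounds shown leave open whether a phenyl bearing an amine or a carboxylic acid, on a double-bonded chain carbon bound to a double-bonded ring carbon, would move the number beyond the scatter. They also leave open what a longer chain in place of the phenyl would do at this position, and whether the same change to the remaining 2-fluorophenyl would read the same.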